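Replacing the amide arm of compound 2 with an aryl ester

The source may hold more compounds than are shown below. What is called first, only, known or untested is meant among the compounds shown, and "the series" means these compounds.

Of the compounds shown here, three share one core and have been measured in an assay on HL-60 cells for agonist activity at vitamin D3 receptor (Homo sapiens), read by microscopy, with a stated time of 96 h; on this read-out higher numbers stand for an effect only at larger amounts of compound and lower numbers for an effect already at smaller amounts. Compound 1 `CC[C@@H](C)[C@H](NC(=O)c1ccc(C(CC)(CC)c2ccc(OCC(=O)C(C)(C)C)c(C)c2)n1CC)C(=O)OC` gives 590 nM. Compound 2 `CC[C@@H](C)[C@H](NC(=O)c1ccc(C(CC)(CC)c2ccc(OCC(O)C(C)(C)C)c(C)c2)n1CC)C(=O)OC` gives 26 nM, the lowest number of the three, with a 23-fold lower number from compound 1 to compound 2 (1.36 log units; beyond the scatter) separating it from its nearest neighbour. Compound 3 `CCn1c(C(=O)N(C)CC(=O)O)ccc1C(CC)(CC)c1ccc(OCC(=O)C(C)(C)C)c(C)c1` gives 1390 nM, and the change from compound 1 to compound 3 brought a 2.4-fold higher number from compound 1 to compound 3 (0.37 log units; beyond the scatter).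

Compound 4 `CCn1c(C(=O)Oc2ccc(CCO)cc2)ccc1C(CC)(CC)c1ccc(OCC(O)C(C)(C)C)c(C)c1` has not yet been measured. It differs from compound 2 in one place: a group of 10 heavy atoms (8 carbon, 2 oxygen; one six-membered aromatic ring of carbon only) in place of a group of 10 heavy atoms (7 carbon, 1 nitrogen, 2 oxygen; no ring), on a carbonyl carbon. Within the data shown here, of the measured steps, only the one from compound 1 to compound 3 touches the same carbonyl carbon, and there the swap of the amino group made a modest step toward higher numbers, a 2.4-fold higher number from compound 1 to compound 3 (0.37 log units; beyond the scatter). The step from compound 1 to compound 2 concerns the other end of the molecule and compound 4 keeps the 1-hydroxy-2,2-dimethylpropyl group of compound 2, so that large gain is assumed to carry over. The group entering compound 4 is larger in its ring content than anything tried at this position, which adds uncertainty.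

Because a 2.4-fold higher number from compound 1 to compound 3 (0.37 log units; beyond the scatter) was modest, compound 4 is expected to land somewhat above compound 2, at about 80 nM with a likely range of 20 nM to 400 nM. That expected change corresponds to a 3.1-fold higher number from compound 2 to compound 4 (0.49 log units; beyond the scatter).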

Compound 4, half-maximal effective concentration: 5100 nM
The estimate for compound 4 lay 64-fold (1.80 log units) below the measured number; the measured number lies above the stated range.
By their numbers in this assay, from the lowest: compound 2; then compound 1; then compound 3; then compound 4.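

At this carbonyl carbon in this assay, replacing the amino arm with the ring-bearing ester arm brought a 200-fold higher number from compound 2 to compound 4 (2.29 log units; beyond the scatter), a far larger change than the earlier swap of one amino group for another, which gave a 2.4-fold higher number from compound 1 to compound 3 (0.37 log units; beyond the scatter). The arm that leaves and the arm that enters both hold 10 heavy atoms, with the same hydrogen-bond donor and acceptor counts and no net charge, so these counts alone do not follow the read-out in this pair. The entering arm also joins through oxygen rather than nitrogen, carries a six-membered aromatic ring and has no defined stereocentres, and no measurement here explains the change or assigns it to any one of these differences.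

The compounds shown leave open whether the large step belongs to the ester link or to the aromatic ring, a question that an amide carrying the same ring-bearing arm could help to settle. From the compounds shown here alone, how a carboxylic acid on this carbonyl carbon would read, with the 1-hydroxy-2,2-dimethylpropyl group kept, also stays open.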